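The compounds below may be only part of what the source reports. "The series", "measured", "known", "first", "only" and "open" are said of these compounds alone.

Measured compounds:
compound 1, `O=C1C(NC2CCCC2)=CC(=O)c2c1nc1n2[C@H]2OC[C@@H](O)[C@H]2OC1`, > 16000 nM
compound 2, `Cc1ccc(NC2=CC(=O)c3nc4n(c3C2=O)[C@H]2OC[C@@H](O)[C@H]2OC4)cc1`, 1660 nM

Compound 1 stands at the limit of > 16000 nM in this assay, at which 1 of the 2 values shown sits, in a functional assay on MCF7 cells (Homo sapiens) for inhibition, read by sulforhodamine B assay (on this read-out higher numbers stand for weaker inhibition and lower numbers for stronger inhibition), so for compound 1 the value > 16000 nM is a limit of the assay and not a number. Compound 2 gives 1660 nM in this assay. Compound 3, `O=C1C(NC2CCCCC2)=CC(=O)c2c1nc1n2[C@H]2OC[C@@H](O)[C@H]2OC1`, is not yet measured; it differs from compound 1 by cyclohexyl in place of cyclopentyl on an amine nitrogen. No measured step of this kind exists among these compounds, and the change is expected to bring nothing beyond the scatter, as in a step that the limit leaves unreadable from compound 1 to compound 3. Compound 3 is therefore estimated at 20000 nM in this assay, between 5000 nM and 60000 nM.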

Compound 3, half-maximal inhibitory concentration: > 16000 nM
Compound 3 ended at the assay's limit; the forecaster's own chance of this, stated with the estimate: 70%; the middle value does not contradict the limit.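

No step can be read from compound 1 to compound 3 because both values are limits of the assay and not numbers: the limit of > 16000 nM in this assay, at which 2 of the 3 values shown sit.

The compounds shown leave open whether cyclohexyl and cyclopentyl on an amine nitrogen differ at all in this assay.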